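This account rests on a few compounds, and the source may have more. Where it says the series, first, only, none or still open, it means among the compounds named here.

In an ADME assay on A549 cells (Homo sapiens) for cytotoxicity, read by CellTiter-Glo (on this read-out higher numbers stand for lower toxicity in this test and lower numbers for higher toxicity in this test), the three measured compounds share one core and differ only in the group carried on the far aromatic ring. Compound 3 `Cc1c(Cc2ccc(-c3ccccc3C#N)cc2)c(=O)oc2cc(OCC(O)CN3CCC(C(N)=O)CC3)ccc12` gives 33200 nM, the lowest of the two numbers shown. Compound 1 `Cc1noc(C)c1-c1ccc(Cc2c(C)c3ccc(OCC(O)CN4CCC(C(N)=O)CC4)cc3oc2=O)cc1` gives 36900 nM, and the difference a 1.1-fold lower number from compound 1 to compound 3 (0.05 log units; within the scatter) lies within the scatter. Compound 2 `Cc1c(Cc2ccc(-c3ccccc3)cc2)c(=O)oc2cc(OCC(O)CN3CCC(C(N)=O)CC3)ccc12` reaches only a limit of this assay, > 100000 nM, as noted in the limit of > 100000 nM in this assay, at which 1 of the 3 values shown sits. The steps of an at least 2.7-fold higher number from compound 1 to compound 2 (0.43 log units; beyond the scatter) and an at least 3.0-fold lower number from compound 2 to compound 3 (0.47 log units; beyond the scatter) are both beyond the scatter, so the bare phenyl stands apart from the two substituted aryl groups.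

Compound 4 `Cc1c(Cc2ccc(-c3ccc(C=O)c(F)c3)cc2)c(=O)oc2cc(OCC(O)CN3CCC(C(N)=O)CC3)ccc12` has not been measured. Its change from compound 3 is 3-fluoro-4-formylphenyl in place of 2-cyanophenyl on an aromatic carbon. Like the cyano group and the dimethyloxazole, the new group keeps one hydrogen-bond acceptor on the outer ring, and compounds 1 and 3 sit close together. The step of a 1.2-fold higher number from compound 3 to compound 4 (0.08 log units; within the scatter) is therefore expected to stay within the scatter, and compound 4 is estimated at 40000 nM, between 15000 nM and 100000 nM.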

Compound 4, half-maximal cytotoxic concentration: 62400 nM
The estimate for compound 4 lay 1.6-fold (0.19 log units) below the measured number; measured number inside the range.
By their numbers in this assay, from the lowest: compounds 3, 1 and 4 (each within the scatter of the next). At a limit, above all of these: compound 2.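

At this place on the far aromatic ring, 3-fluoro-4-formylphenyl in place of 2-cyanophenyl gives a 1.9-fold higher number from compound 3 to compound 4 (0.27 log units; within the scatter), and in place of 3,5-dimethyl-1,2-oxazol-4-yl it gives a 1.7-fold higher number from compound 1 to compound 4 (0.23 log units; within the scatter), so in this assay three different substituted outer groups cannot be told apart. Against the bare phenyl the step is an at least 1.6-fold lower number from compound 2 to compound 4 (0.20 log units; that floor lies within the scatter), so compound 4, unlike compounds 1 and 3, is not clearly separated from compound 2. The entry for compound 2 is a limit, not a number: the limit of > 100000 nM in this assay, at which 1 of the 4 values shown sits.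

The compounds shown leave open whether the fluorine or the formyl alone would read the same as the two together on the outer ring. They also leave open how an amine or a carboxylic acid at this place would read.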